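Swapping a Piperidine Amide for an Imidazole Amide

The source may hold more compounds than are shown below. What is called first, only, known or untested is meant among the compounds shown, and "the series" means these compounds.

Compound 1 `COC(=O)C1=C(C)NC(C)=C(C(=O)OC)C1c1ccc(OCC(=O)N2CCCCC2)c(OC)c1` was tested in an assay on cells for inhibition of Voltage-gated L-type calcium channel (Rattus norvegicus), read by fluorescence and calcium flux, with stated times of 30 min and 2 min (on this read-out higher numbers stand for weaker inhibition and lower numbers for stronger inhibition), and gave 10000 nM. Compound 2 `COC(=O)COc1cccc(C2C(C(=O)OC)=C(C)NC(C)=C2C(=O)OC)c1`, which carries a different side chain on the shared core, gave 10000 nM in this assay, so at the digits shown compound 1 stands level with compound 2, within the usual scatter of such measurements. Compound 3 `COC(=O)C1=C(C)NC(C)=C(C(=O)OC)C1c1ccc(OCC(=O)n2ccnc2)c(OC)c1` has not yet been measured. It differs from compound 1 in one place: 1H-imidazol-1-yl in place of piperidin-1-yl on a carbonyl carbon. Among the compounds with values here, no measured pair of compounds shows this kind of change, so there is no step to lean on, and the two values known here are the same. The expected step in this assay is no change at the digits printed from compound 1 to compound 3 (within the scatter), none beyond the scatter. Compound 3 is therefore estimated at 10000 nM, with a likely range from 4000 nM to 25000 nM.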

Compound 3, half-maximal inhibitory concentration: 10100 nM
Beside the measured number, compound 3's estimate is 1.0-fold (0.00 log units) below it; the measured number falls inside the stated range.
By their numbers in this assay, from the lowest: compounds 1, 2 and 3 (each within the scatter of the next).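

In this assay, within the data shown here, compound 1 and compound 3 stand level (a 1.0-fold higher number from compound 1 to compound 3 (0.00 log units; within the scatter)), the first reading of a change at this carbonyl carbon. On paper the exchange is not a small one: piperidin-1-yl, a six-membered non-aromatic ring with 0 hydrogen-bond acceptors, gives way to 1H-imidazol-1-yl, a five-membered aromatic ring with 2 hydrogen-bond acceptors, yet the two numbers stay within the usual scatter. No measurement at hand offers an explanation for this result.

The compounds shown leave open whether any other group on this carbonyl carbon, such as morpholin-4-yl, dimethylamino or a free hydroxyl that would make a carboxylic acid, would separate itself from these values. They also leave open whether a longer chain between the carbonyl and the ring oxygen would do so.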